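Replacing the 4-bromophenyl group of compound 2

The compounds below may be only part of what the source reports. "The series", "measured", "known", "first", "only" and "open" are said of these compounds alone.

In a functional assay on HepG2 cells (Homo sapiens) for inhibition, read by MTT assay (on this read-out higher numbers stand for weaker inhibition and lower numbers for stronger inhibition), compound 1 (`COc1cc2ncnc(Nc3ccc(NC(=O)c4ccccc4Cl)cc3)c2cc1OC`) gives 26000 nM and compound 2 (`COc1cc2ncnc(Nc3ccc(NC(=O)c4ccc(Br)cc4)cc3)c2cc1OC`) gives 35000 nM, so the two cannot be told apart. Within the data shown here, the only measured step, a 1.3-fold higher number from compound 1 to compound 2 (0.13 log units; within the scatter), also exchanges the group on a carbonyl carbon. Compound 3 (`COc1cc2ncnc(Nc3ccc(NC(=O)c4cc(F)ccc4Br)cc3)c2cc1OC`) carries 2-bromo-5-fluorophenyl in place of 4-bromophenyl on that carbonyl carbon: 2-bromo-5-fluorophenyl in place of 4-bromophenyl on a carbonyl carbon. Among the measured compounds shown here, with that single small step as the only guide, no change beyond the scatter is expected in this assay. The estimated step is a 1.2-fold lower number from compound 2 to compound 3 (0.08 log units; within the scatter). For compound 3 the expected value is 29000 nM, with an estimated range of 14000 nM to 60000 nM.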

Compound 3, half-maximal inhibitory concentration: 22000 nM
Compound 3: middle estimate off by 1.3-fold (0.12 log units), on the high side; low and high end bracket the measured number.
By their numbers in this assay, from the lowest: compounds 3, 1 and 2 (each within the scatter of the next).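

In this assay the second halogen of the 2-bromo-5-fluorophenyl group brings a 1.6-fold lower number from compound 2 to compound 3 (0.20 log units; within the scatter) and a 1.2-fold lower number from compound 1 to compound 3 (0.07 log units; within the scatter) so the number does not respond to this change. Compounds 1, 2 and 3, each with a halogenated phenyl group on this carbonyl carbon, cannot be told apart. Nothing available explains this result.

What the compounds shown leave open is whether a group without a halogenated phenyl ring on that carbonyl carbon, such as a simple alkyl chain, an amine or a carboxylic acid, would move the number beyond the scatter.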